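This account rests on a few compounds, and the source may have more. Where it says the series, first, only, none or still open, it means among the compounds named here.

Measured so far:
compound 1 `CCOc1ccc(NC(=O)CSc2c[nH]c3ccc(Br)cc23)cc1`: 71400 nM
compound 2 `CCN(CC)c1nc(NCC(=O)NCc2ccccc2)c2ccccc2n1`: > 100000 nM

In an ADME assay on A549 cells (Homo sapiens) for cytotoxicity, read by CCK-8 assay, with a stated time of 48 h (a higher number here means that more compound is tolerated, a lower number that less compound is tolerated), compound 1 gives 71400 nM. For compound 2 the result is only a limit of the assay, > 100000 nM, not a number; this is the limit of > 100000 nM in this assay, at which 1 of the 2 values shown sits. Compound 3 `O=C(CNc1nc(N2CCc3ccccc3C2)nc2ccccc12)NCc1ccccc1` differs from compound 2 in one place: 1,2,3,4-tetrahydroisoquinolin-2-yl in place of diethylamino on an aromatic carbon. Among the measured compounds shown here, no measured pair covers this change, and no guide to its size exists. A modest shift toward less tolerance, possibly inside the scatter, is expected in this assay, with an estimated step of an at least 1.6-fold lower number from compound 2 to compound 3 (0.22 log units; that floor lies within the scatter). Compound 3 is expected to give 60000 nM in this assay, between 20000 nM and 150000 nM.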

Compound 3, half-maximal cytotoxic concentration: 12800 nM
For compound 3 the middle estimate is 4.7-fold (0.67 log units) above the measured one; measured number outside the range, below it.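

In this assay, putting 1,2,3,4-tetrahydroisoquinolin-2-yl in place of diethylamino, on the aromatic carbon between two ring nitrogen atoms, gives an at least 7.8-fold lower number from compound 2 to compound 3 (0.89 log units; beyond the scatter). So the group at this position can shift cell tolerance well beyond the usual scatter. Compound 2 gives > 100000 nM, which is a limit of the assay and not a number, so the step has only a lower bound.

The compounds shown do not separate the non-aromatic ring from the aromatic ring in the entering group. A piperidin-1-yl group, which has a six-membered non-aromatic ring and no aromatic ring, would help tell them apart.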